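This account rests on a few compounds, and the source may have more. Where it says the series, first, only, none or still open, it means among the compounds named here.

Measured so far in a functional assay on HeLa cells (Homo sapiens) for antiproliferative activity, read by cell counting, with a stated time of 2 days; on this read-out higher numbers stand for weaker inhibition and lower numbers for stronger inhibition:
Compound 1, `COc1cc(C(=O)c2sc(Nc3ccc(F)cc3)nc2N)cc(OC)c1OC`, gives 440 nM.
Compound 3, `COc1cc(C(=O)c2sc(Nc3ccc(Cl)cc3)nc2N)cc(OC)c1OC`, gives 180 nM.
Compound 2, `Nc1nc(Nc2ccc(Cl)cc2)sc1C(=O)c1ccccc1`, gives only a limit of the assay, > 10000 nM.

Compound 1 and compound 3 share one core and differ in a single place: fluoro in place of chloro on an aromatic carbon. That change made a 2.4-fold higher number from compound 3 to compound 1 (0.39 log units; beyond the scatter), so inhibition grew weaker. The core of compound 2 differs from the core of compound 3, but that difference is not broken down here. Compound 4, `Nc1nc(Nc2ccc(F)cc2)sc1C(=O)c1ccccc1`, has not yet been measured; it is reached from compound 2 by the same change, at the same kind of place: fluoro in place of chloro on an aromatic carbon. Compound 2 sits at the limit of > 10000 nM in this assay, at which 1 of the 3 values shown sits. The change is expected to give a step that the limit leaves unreadable from compound 2 to compound 4, because the earlier one gave a 2.4-fold higher number from compound 3 to compound 1 (0.39 log units; beyond the scatter). Compound 4 is therefore expected to remain at the limit, estimated around 25000 nM, within 8000 nM to 100000 nM.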

Compound 4, half-maximal inhibitory concentration: > 10000 nM
Compound 4: no number, only a limit (the forecaster's own chance of this, stated with the estimate: 85%); the middle value does not contradict the limit.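

Compound 2 and compound 4 both give only a limit rather than a number, so no step can be read between them: the limit of > 10000 nM in this assay, at which 2 of the 4 values shown sit.

Going by these compounds, what the change from 4-chlorophenyl to 4-fluorophenyl does to inhibition on the core of compound 2 remains open.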